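The source may report more compounds than this note shows. Statements on the series, on what has been measured and on what is new or still open speak of the compounds shown alone.

Working notes on the series. Two compounds sharing the core have numbers in an ADME assay on the whole organism with Oryza sativa as the target, tested at 1 uM; on this read-out lower numbers stand for a stronger effect and higher numbers for a weaker effect at the one concentration tested. Compound 1, `CCc1ccc(NC(=O)N[C@H](C)c2ccccc2)cc1`, gives 47%. Compound 2, `CCCCCCc1ccc(NC(=O)N[C@H](C)c2ccccc2)cc1`, gives 101%. Among the compounds with values here, the single measured step between them is a number 54 percentage points higher from compound 1 to compound 2 (beyond the scatter). Within the data shown here, on these two numbers compound 2 stands highest, with compound 1 the only other compound and well below it.

Compound 3, `C[C@@H](NC(=O)Nc1ccc(C(F)(F)F)cc1)c1ccccc1`, has not been measured in this assay. It differs from compound 2 in one place: trifluoromethyl in place of hexyl on an aromatic carbon. Among the measured compounds shown here, the group that enters is not an alkyl chain, so no measured step covers this change directly. For the measured compounds named here, the only step available, a number 54 percentage points higher from compound 1 to compound 2 (beyond the scatter), concerns a lengthened chain on the same core; compound 3 removes that chain entirely and puts a group of fewer heavy atoms in its place, so the expectation is a move back toward the lower region, held with less confidence than a direct precedent would allow. For compound 3 a step of a number 41 percentage points lower from compound 2 to compound 3 (beyond the scatter) in this assay is expected. Compound 3 is estimated at 60%, within a range from 35% to 95%.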

Compound 3, a percentage reported as activity, at one concentration (the size of the read-out at that concentration, not a potency): 89%
Compound 3: the middle estimate sits 29 percentage points below what was measured, and the stated range covers the measured number.
By their numbers in this assay, from the lowest: compound 1; then compound 3; then compound 2.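

In this assay, a high number at this aromatic carbon does not depend on a long alkyl chain: trifluoromethyl in place of hexyl gives only a modest change, a number 12 percentage points lower from compound 2 to compound 3 (beyond the scatter), while trifluoromethyl in place of ethyl gives a large one, a number 42 percentage points higher from compound 1 to compound 3 (beyond the scatter). Among these three compounds, the group that enters with compound 3 therefore sits much closer to hexyl than to ethyl on this read-out, despite having 4 heavy atoms against 6 for hexyl and no chain, so compound 1 alone holds the low number and chain length by itself does not account for the three values. No supporting measurement bears on why these groups place the compounds as they do.

The compounds shown leave open where a propyl or butyl chain would fall between ethyl and hexyl at this aromatic carbon, and so whether the rise along the alkyl chains is gradual or abrupt. They also leave open whether a methoxy group, a nitrile, an amine or a carboxylic acid at the same carbon would stay near compound 3 or come down toward compound 1.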